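This account rests on a few compounds, and the source may have more. Where it says the series, first, only, none or still open, it means among the compounds named here.

Compound 1 `Cc1ccc(Cn2c(/C=C3\SC(=S)N(CC(=O)O)C3=O)nc3cc(Cl)ccc32)cc1`, compound 2 `Cc1ccc(Cn2c(/C=C3\SC(=S)N(CC(=O)O)C3=O)nc3ccc(Cl)cc32)cc1` and compound 3 `Cc1ccc(Cn2c(/C=C3\SC(=S)N(CC(=O)O)C3=O)nc3cc(F)ccc32)cc1` share a core; how the core of compound 2 differs from that of compound 1 is not broken down here. In a functional assay on Raji cells (Homo sapiens) for cytotoxicity, read by MTT assay, with a stated time of 48 h (on this read-out higher numbers stand for weaker inhibition and lower numbers for stronger inhibition), compound 1 gives 20900 nM, compound 2 gives 2790 nM and compound 3 gives 3280 nM. Compound 3 differs from compound 1 by fluoro in place of chloro on an aromatic carbon, which brought a 6.4-fold lower number from compound 1 to compound 3 (0.80 log units; beyond the scatter). Compound 4 `Cc1ccc(Cn2c(/C=C3\SC(=S)N(CC(=O)O)C3=O)nc3ccc(F)cc32)cc1` is not yet measured and differs from compound 2 by the same change, (fluoro in place of chloro on an aromatic carbon). Because compound 2 already gives 2790 nM and lies close to compound 3, a smaller step is expected in this assay, a 1.9-fold lower number from compound 2 to compound 4 (0.27 log units; within the scatter). Compound 4 is therefore expected at 1500 nM, within 400 nM to 5000 nM.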

Compound 4, half-maximal inhibitory concentration: 2440 nM
Estimate against measurement, compound 4: 1.6-fold (0.21 log units) below; the measured number falls inside the stated range.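

In this assay, fluoro in place of chloro on an aromatic carbon gives a 1.1-fold lower number from compound 2 to compound 4 (0.06 log units; within the scatter), so on this core the swap cannot be told apart from the normal variation between repeat measurements. The size of the step therefore does not carry over from one core to the other: the same change on two cores in this assay, a 6.4-fold lower number (0.80 log units; beyond the scatter) from compound 1 to compound 3 and a 1.1-fold lower number (0.06 log units; within the scatter) from compound 2 to compound 4, 5.6-fold (0.75 log units) apart, beyond the scatter of two such steps

Going by these compounds alone, these two pairs show only that the step can depend on the core; they do not explain the gap or predict the step on any further core. Among the compounds shown, this position holds only chloro or fluoro. From the compounds shown here alone, how a bromo, methoxy or amine group there would read remains open.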